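The source may report more compounds than this note shows. Statements on the series, on what has been measured and on what is new or still open speak of the compounds shown alone.

Measured in a functional assay on PANC-1 cells (Homo sapiens) for inhibition, read by MTT assay, with a stated time of 24 h; a lower number here means a stronger inhibitor, a higher number a weaker inhibitor:
- Compound 1 `CC1(C)[C@H]2CC[C@]1(C)N(Cc1cn(-c3ccc(C#N)cc3)nn1)C(=O)C2`: 250 nM
- Compound 2 `CC1(C)[C@H]2CC[C@]1(C)N(Cc1cn(-c3ccc(F)cc3)nn1)C(=O)C2`: 110 nM
- Compound 3 `CC1(C)[C@H]2CC[C@]1(C)N(Cc1cn(-c3ccccc3Cl)nn1)C(=O)C2`: 270 nM

Two steps place compound 3: a 1.1-fold higher number from compound 1 to compound 3 (0.03 log units; within the scatter), and a 2.5-fold higher number from compound 2 to compound 3 (0.39 log units; beyond the scatter). Compound 4 `Cc1ccc(-n2cc(CN3C(=O)C[C@@H]4CC[C@@]3(C)C4(C)C)nn2)cc1` carries 4-methylphenyl in place of 2-chlorophenyl on an aromatic nitrogen. Among the measured compounds shown here, no measured compound has 4-methylphenyl, so these steps, together with a 2.3-fold lower number from compound 1 to compound 2 (0.36 log units; beyond the scatter), are only an indirect guide. Each exchange of this group has been modest or lost in the scatter, so only a small step is expected in this assay, leaning towards a lower number. The estimated change is a 1.6-fold lower number from compound 3 to compound 4 (0.20 log units; within the scatter). Compound 4 is expected near 170 nM, with an estimated range of 70 nM to 400 nM.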

Compound 4, half-maximal inhibitory concentration: 270 nM
Compound 4: the middle estimate sits 1.6-fold (0.20 log units) below what was measured, within the range that was stated.
By their numbers in this assay, from the lowest: compound 2; then compounds 1, 3 and 4 (each within the scatter of the next).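

In this assay, 4-methylphenyl in place of 2-chlorophenyl on the aromatic nitrogen leaves the number unchanged (no change at the digits printed from compound 3 to compound 4 (within the scatter)). Methyl in place of cyano also stays within the scatter (a 1.1-fold higher number from compound 1 to compound 4 (0.03 log units; within the scatter)), whereas methyl in place of fluoro gives a modest rise (a 2.5-fold higher number from compound 2 to compound 4 (0.39 log units; beyond the scatter)), leaving compound 2 as the only one set apart from the others. No available evidence accounts for this difference. From the compounds shown here alone, whether an amine, a methoxy group or a carboxylic acid on this phenyl ring would match compound 2 stays open.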